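A Fluorine on the Benzyl Ring of Compound 1

This account rests on a few compounds, and the source may have more. Where it says the series, first, only, none or still open, it means among the compounds named here.

Going by the values given here, compound 1 `CCOC(=O)N1[C@@H]2C=C[C@@](OC)(C(=O)c3c2cc(OC)c(OC)c3OCc2ccccc2)N1C(=O)OCC` is the one compound of this set that gives a number in an ADME assay on KB cells (Homo sapiens) for cytotoxicity; a lower number here means that less compound is needed, a higher number that more compound is needed for the effect: compound 1 gives 215 ug/mL. Compound 2 `COC(=O)N1[C@@H]2C=C[C@@](OC)(C(=O)c3c2cc(OC)c(OC)c3OCc2ccccc2)N1C(=O)OC` reaches only a limit of the assay in this assay, where compound 2 gives > 300 ug/mL. Compound 3 `COC(=O)N1[C@@H]2C=C[C@@](OC)(C(=O)c3c2cc(OC)c(OC)c3OCc2ccc(OC)cc2)N1C(=O)OC` likewise stops at a limit in this assay, with compound 3 at > 300 ug/mL. Among the compounds with values here, the one step between measured compounds that differ in a single place, a step that the two limits leave unreadable from compound 2 to compound 3, therefore cannot be read, since both of its ends rest at the limit of > 300 ug/mL in this assay, at which 2 of the 3 values shown sit. Compound 4 `CCOC(=O)N1[C@@H]2C=C[C@@](OC)(C(=O)c3c2cc(OC)c(OC)c3OCc2ccccc2F)N1C(=O)OCC` differs from compound 1 in one place: fluoro in place of hydrogen on an aromatic carbon. Within the data shown here, no measured step involves a fluoro group, so none bears directly on this change, and the single step that was measured is unreadable. The account therefore expects no shift beyond the usual scatter in this assay, and the estimate for compound 4 is 230 ug/mL, between 110 ug/mL and 450 ug/mL, a step of a 1.1-fold higher number from compound 1 to compound 4 (0.03 log units; within the scatter) that is expected to stay within the scatter.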

Compound 4, concentration for half-maximal effect: 99.7 ug/mL
The estimate for compound 4 lay 2.3-fold (0.36 log units) above the measured number; measured number below the stated range.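

In this assay, going by these compounds alone, fluoro in place of hydrogen on an aromatic carbon, ortho to a large group, gives a 2.2-fold lower number from compound 1 to compound 4 (0.33 log units; beyond the scatter) and so supplies the first readable step of the set. It shows that the benzyl ring of compound 1 is a place where a change of a single heavy atom can be read, which the earlier step could not show, since both of its ends are limits: the limit of > 300 ug/mL in this assay, at which 2 of the 4 values shown sit. Nothing shown bears on why fluoro in this place has this effect.

From the compounds shown here alone, whether a chloro or a methyl group in the same place would give a similar step remains open, as does the outcome of fluoro on another carbon of this ring. Also open, going by these compounds, is whether the fluoro step would carry over to the core with methoxycarbonyl groups in place of the ethoxycarbonyl groups.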